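The compounds below may be only part of what the source reports. "The series", "measured", "known", "first", "only" and "open" are said of these compounds alone.

Measured compounds:
compound 1 `Cc1ccc(S(=O)(=O)Nc2ccc3oc(-c4ccccc4)nc3c2)cc1` gives > 63000 nM
compound 2 `O=S(=O)(Nc1ccc2oc(-c3ccccc3)nc2c1)c1ccc(C(F)(F)F)cc1` gives > 63000 nM
compound 3 `Cc1ccccc1S(=O)(=O)Nc1ccc(-c2nc3ccccc3o2)cc1` gives > 63000 nM

All three sulfonamides were tested in an assay on isolated protein for inhibition of malate dehydrogenase, mitochondrial (Sus scrofa), with stated times of 45 min and 30 min; a higher number here means a weaker inhibitor, a lower number a stronger inhibitor. For compound 1 the reading > 63000 nM is a limit of the assay and not a number. Compound 2 likewise stops at a limit, > 63000 nM. Compound 3 also sits at a limit, > 63000 nM. The change from compound 1 to compound 2 is trifluoromethyl in place of methyl on an aromatic carbon; the step is a step that the two limits leave unreadable from compound 1 to compound 2, because of the limit of > 63000 nM in this assay, at which 3 of the 3 values shown sit. Compound 3 has the same atoms as compound 1, joined differently; the difference between the two cores is not broken down here.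

Compound 4 `O=S(=O)(Nc1ccc(-c2nc3ccccc3o2)cc1)c1ccccc1C(F)(F)F` has not yet been measured in this assay. It differs from compound 3 by trifluoromethyl in place of methyl on an aromatic carbon. This is the same kind of change as that from compound 1 to compound 2, though not the same: in compound 2 the group enters para to a large group, in compound 4 ortho to a large group. The step from compound 3 to compound 4 is expected to be a step that the limit leaves unreadable from compound 3 to compound 4, an expectation resting on compound 3 reading only a limit, > 63000 nM. Compound 4 is estimated at 100000 nM, most likely another limit.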

Compound 4, half-maximal inhibitory concentration: > 63000 nM
Compound 4: only a limit was reported; the forecaster's own chance of this, stated with the estimate: 85%; the middle value does not contradict the limit.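

In this assay compound 4 gives > 63000 nM, which is a limit of the assay and not a number. No step can be read between compound 3 and compound 4, because both stop at the same limit: the limit of > 63000 nM in this assay, at which 4 of the 4 values shown sit. The compounds shown leave open what effect, if any, trifluoromethyl in place of methyl has on inhibition.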